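The source may report more compounds than this note shows. Statements on the series, on what has been measured and on what is new or still open speak of the compounds shown alone.

In a functional assay on HCT-116 cells (Homo sapiens) for cytotoxicity, read by sulforhodamine B assay, with a stated time of 48 h (on this read-out lower numbers stand for stronger inhibition and higher numbers for weaker inhibition), compound 1 (`CCCCNC(=O)N1Cc2c(NC(=O)c3ccc(F)cc3)nn(C(=O)c3ccccc3)c2C1`) gives 30800 nM and compound 2 (`CCCCNC(=O)N1Cc2c(NC(=O)c3ccc(OC)cc3)nn(C(=O)C3CC3)c2C1`) gives 65500 nM as the higher of the two numbers, a gap beyond the scatter. Compound 3 (`CCCCNC(=O)N1Cc2c(NC(=O)c3ccc(OC)cc3)nn(C(=O)c3ccccc3)c2C1`) differs from compound 2 by phenyl in place of cyclopropyl on a carbonyl carbon with phenyl in place of cyclopropyl on a carbonyl carbon. For the measured compounds named here, no measured step isolates this change. Compound 1 also carries benzoyl and stands at 30800 nM in this assay so a small move towards lower numbers is expected. The estimated change is a 1.6-fold lower number from compound 2 to compound 3 (0.19 log units; within the scatter) and may stay within the scatter. Compound 3 is expected at 42000 nM within a range of 18000 nM to 85000 nM for now.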

Compound 3, half-maximal inhibitory concentration: 25300 nM
Compound 3: middle estimate off by 1.7-fold (0.22 log units), on the high side; the measured number falls inside the stated range.
By their numbers in this assay, from the lowest: compounds 3 and 1 (each within the scatter of the next); then compound 2.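

In this assay, for the compounds shown here, phenyl in place of cyclopropyl on the carbonyl carbon gives a 2.6-fold lower number from compound 2 to compound 3 (0.41 log units; beyond the scatter), the first reading of this change with the rest of the structure held constant. Methoxy in place of fluoro on an aromatic carbon gives a 1.2-fold lower number from compound 1 to compound 3 (0.09 log units; within the scatter), so this pair does not separate. No measured evidence accounts for either step.

Only phenyl and cyclopropyl are compared on that carbonyl carbon, leaving open how a pyridyl ring or a longer alkyl chain would read there. As far as these compounds go, an amine in place of methoxy on the aromatic carbon also remains open.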